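Nitro for amino on the aryl of compound 1

The source may hold more compounds than are shown below. What is called first, only, known or untested is meant among the compounds shown, and "the series" means these compounds.

The series shares one core carrying three methoxy groups, with a substituted phenyl on the aromatic nitrogen. Compound 1 `COc1cc(-c2ncnn2-c2cccc(N)c2)cc(OC)c1OC` bears a 3-aminophenyl there. In a functional assay on MCF7 cells (Homo sapiens) for antiproliferative activity, read by MTT assay, with a stated time of 72 h (on this read-out higher numbers stand for weaker inhibition and lower numbers for stronger inhibition), compound 1 gives > 10000 nM, which is a limit of the assay and not a number. Compound 2 `COc1cc(-c2ncnn2-c2ccc(Cl)c(Cl)c2)cc(OC)c1OC` carries a 3,4-dichlorophenyl; in this assay compound 2 gives > 10000 nM, again a limit. Compound 3 `COc1cc(-c2ncnn2-c2ccc(Cl)cc2Cl)cc(OC)c1OC` carries a 2,4-dichlorophenyl; in this assay compound 3 gives > 10000 nM, also a limit. Accordingly the steps a step that the two limits leave unreadable from compound 1 to compound 2, a step that the two limits leave unreadable from compound 1 to compound 3 and a step that the two limits leave unreadable from compound 2 to compound 3 cannot be read, because of the limit of > 10000 nM in this assay, at which 3 of the 3 values shown sit.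

Compound 4 `COc1cc(-c2ncnn2-c2cccc([N+](=O)[O-])c2)cc(OC)c1OC` differs from compound 1 as follows: nitro in place of amino on an aromatic carbon. Among the compounds with values here, no measured step touches this group, and all three measured compounds sit at the limit, so no direction or size of step can be drawn from them for this assay. The only expectation the data support is that compound 4 behaves like its three measured neighbours. The step from compound 1 to compound 4 is therefore expected to be a step that the limit leaves unreadable from compound 1 to compound 4, with wide uncertainty. For compound 4 the estimate in this assay is 15000 nM, spanning 4000 nM to 60000 nM, with a high chance that only a limit is reported.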

Compound 4, half-maximal inhibitory concentration: > 10000 nM
Compound 4 was reported as a limit; the forecaster's own chance of this, stated with the estimate: 75%; the middle value does not contradict the limit.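

In this assay compound 4 gives > 10000 nM, a limit and not a number, so the step from compound 1 to compound 4 cannot be read, and the reason is the shared limit: the limit of > 10000 nM in this assay, at which 4 of the 4 values shown sit.

The compounds shown leave open whether any substituent on this phenyl of the shared core gives a measurable value on this read-out.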